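The source may report more compounds than this note shows. Statements on the series, on what has been measured and on what is new or still open speak of the compounds shown alone.

Measured so far:
- compound 1 `Nc1ccccc1NC(=O)c1ccc(CSC(=S)N2CCN(c3ccc(Cl)cc3)CC2)cc1`: 44.8%
- compound 2 `Nc1ccccc1NC(=O)c1ccc(CSC(=S)N2CCN(c3ccncc3)CC2)cc1`: 77.4%

Both compounds share one core and differ only in the group attached to an amine nitrogen in a ring. In a functional assay on HeLa cells (Homo sapiens) for antiproliferative activity, read by CCK-8 assay, with a stated time of 72 h, tested at 8 uM (on this read-out lower numbers stand for a weaker effect and higher numbers for a stronger effect at the one concentration tested), compound 1 gives 44.8% and compound 2 gives 77.4%. Compound 2 stands highest of the two numbers, and its nearest neighbour is compound 1, which sits a number 32.6 percentage points higher from compound 1 to compound 2 (beyond the scatter) apart.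

Compound 3 `Nc1ccccc1NC(=O)c1ccc(CSC(=S)N2CCN(Cc3ccccc3)CC2)cc1` is not yet measured. Its change from compound 2 is benzyl in place of pyridin-4-yl on an amine nitrogen in a ring. Among the measured compounds shown here, the one measured step that bears on this is the one from compound 1 to compound 2, where an aromatic ring of carbon only with a chlorine was exchanged for pyridin-4-yl and the read-out rose by a number 32.6 percentage points higher from compound 1 to compound 2 (beyond the scatter). Compound 3 again carries an aromatic ring of carbon only, though joined through one extra carbon as benzyl, so a downward step from compound 2 in this assay is expected, likely of a size comparable to the earlier one, estimated as a number 27.4 percentage points lower from compound 2 to compound 3 (beyond the scatter). Compound 3 is therefore expected to give about 50%, within a range of 30% to 72%.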

Compound 3, a percentage reported as inhibition, at one concentration (the size of the read-out at that concentration, not a potency): 31.3%
Beside the measured number, compound 3's estimate is 18.7 percentage points above it; measured number inside the range.
By their numbers in this assay, from the lowest: compound 3; then compound 1; then compound 2.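

In this assay, benzyl in place of pyridin-4-yl on the amine nitrogen in the ring gives a number 46.1 percentage points lower from compound 2 to compound 3 (beyond the scatter) and adds a second carbon-only aromatic group that stands well under the pyridin-4-yl of compound 2; among these three compounds, none goes against that pattern. Benzyl in place of 4-chlorophenyl gives a number 13.5 percentage points lower from compound 1 to compound 3 (beyond the scatter) and shows that the two carbon-only groups are not equivalent at this place either, which leaves compound 3 as the lowest of the three in this assay. Nothing available explains these differences in the read-out.

The step to benzyl changes two things at once, removing the ring nitrogen of pyridin-4-yl and adding the carbon that links the aromatic ring to the amine nitrogen, so these compounds cannot show which change matters more. Pyridin-4-ylmethyl would keep the ring nitrogen together with that linking carbon, while unsubstituted phenyl would separate the effect of the chlorine in compound 1 from that of the linking carbon in compound 3, and how either would read here remains open.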